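A few compounds are considered here, and "the series" means these few. Any claim that something is new, unique, unknown or untested is made for them only; others in the source may bear on it.

Compound 2 `COC(=O)CC(=O)N1N=C(c2ccc(-n3ccnc3)cc2)CC1c1ccc(N(C)C)cc1` gives 2.3% in a functional assay on MDA-MB-231 cells (Homo sapiens) for inhibition, read by sulforhodamine B assay, tested at 10 uM (on this read-out higher numbers stand for more inhibition at the one concentration tested (going by the name of the read-out) and lower numbers for less inhibition), and compound 1 `CN(C)c1ccc(C2CC(c3ccc(-n4ccnc4)cc3)=NN2C(=O)CCCl)cc1` gives 2.1% in the same assay; the two numbers sit within the scatter of each other, so neither compound can be set apart, and both show little inhibition at the tested concentration. Among the compounds with values here, the one measured step, a number 0.2 percentage points higher from compound 1 to compound 2 (within the scatter), changes the chain on the carbonyl bound to the ring nitrogen and stays within the scatter.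

Compound 3 `CN(C)c1ccc(C2CC(c3ccc(-n4ccnc4)cc3)=NN2S(C)(=O)=O)cc1` differs from compound 2 as follows: methylsulfonyl in place of ((methoxycarbonyl)methyl)carbonyl on an amine nitrogen in a ring. Within the data shown here, no measured step replaces a carbonyl-bearing group on that ring nitrogen with a sulfonyl, so the measured step from compound 1 to compound 2 is the only guide, and it was flat. The expectation for compound 3 is therefore a step of a number 0.7 percentage points higher from compound 2 to compound 3 (within the scatter), within the scatter. Compound 3 is estimated at 3%, in the range -8% to 15%.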

Compound 3, a percentage reported as inhibition, at one concentration (the size of the read-out at that concentration, not a potency): 12%
Beside the measured number, compound 3's estimate is 9 percentage points below it; low and high end bracket the measured number.
By their numbers in this assay, from the lowest: compounds 1, 2 and 3 (each within the scatter of the next).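

Compound 3 carries methylsulfonyl on the amine nitrogen in the ring, the only group among the compounds shown that is not joined there through a carbonyl. In this assay this exchange gives a number 9.7 percentage points higher from compound 2 to compound 3 (within the scatter), and against the other carbonyl-bearing chain it gives a number 9.9 percentage points higher from compound 1 to compound 3 (within the scatter). Even this change of the attaching group therefore does not set compound 3 apart from either neighbour, and nothing available bears on a cause for the result.

Open, from the compounds shown here alone, is whether a longer chain on the sulfonyl, a phenylsulfonyl group or a carboxylic acid on the carbonyl chain at this nitrogen would move the number beyond the scatter. Going by these compounds, all three compounds also share the 4-(dimethylamino)phenyl group, so the effect of a methoxy or a chlorine in place of its dimethylamino group remains unknown.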